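Swapping the aryl group on the shared core of compound 2

The compounds below may be only part of what the source reports. "The series", "measured", "known", "first", "only" and "open" are said of these compounds alone.

In a functional assay on MDA-MB-231 cells (Homo sapiens) for antiproliferative activity, read by MTT assay, with a stated time of 48 h (on this read-out lower numbers stand for stronger inhibition and higher numbers for weaker inhibition), compound 1, with the structure `Cc1cnc(Nc2ccc(S(C)(=O)=O)cc2)nc1Nc1nc2ccccc2s1`, gives 14800 nM. Compound 2, the structure `COc1cccc(Nc2ncc(C)c(Nc3nc4ccccc4s3)n2)c1`, carries a 3-methoxyphenyl group on the same nitrogen. In this assay compound 2 is recorded only as a limit of the assay, > 50000 nM, so no number is known for it and it stands at the weak end of what was measured. Of the two values shown, one sits at that limit (the limit of > 50000 nM in this assay, at which 1 of the 2 values shown sits), and the other is the figure for compound 1.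

Compound 3, the structure `Cc1cnc(Nc2ccc(F)cc2)nc1Nc1nc2ccccc2s1`, is not yet measured. It differs from compound 2 in one place: 4-fluorophenyl in place of 3-methoxyphenyl on a nitrogen on an aromatic ring. For the measured compounds named here, no measured pair shows this exact change, so the size and direction of the step can only be guessed. The step from compound 2 to compound 3 in this assay is expected to be an at least 1.6-fold lower number from compound 2 to compound 3 (0.22 log units; that floor lies within the scatter), which would leave compound 3 in the weakly active region. On that basis compound 3 is estimated to give 30000 nM in this assay, with a likely range from 8000 nM to 100000 nM.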

Compound 3, half-maximal inhibitory concentration: > 50000 nM
Compound 3: a limit, no number (the forecaster's own chance of this, stated with the estimate: 40%); at least 1.6-fold (0.22 log units) between middle value and limit.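

In this assay compound 3 is recorded only as a limit of the assay, not as a number. The swap of 3-methoxyphenyl for 4-fluorophenyl on this nitrogen therefore cannot be sized, because both ends of that step are limits: the limit of > 50000 nM in this assay, at which 2 of the 3 values shown sit.

The new information comes from the other comparison, fluoro in place of methylsulfonyl on an aromatic carbon, which gives an at least 3.3-fold higher number from compound 1 to compound 3 (0.52 log units; beyond the scatter) and lies beyond the usual scatter. Among these three compounds, only compound 1, which carries the methylsulfonyl group, gives a real number, while neither the 3-methoxyphenyl nor the 4-fluorophenyl group brings a compound within the measured range.

As far as these compounds go, how far compound 2 and compound 3 lie past the limit remains unknown, as does whether they differ from each other at all. From the compounds shown here alone, it is also open whether the number seen for compound 1 depends on the methylsulfonyl group specifically, or would persist with a sulfonamide or a carboxylic acid on that aromatic carbon instead.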